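Isobutyl for isopropyl: a small step expected

The source may hold more compounds than are shown below. What is called first, only, known or untested is meant among the compounds shown, and "the series" means these compounds.

For the measured compounds named here, in a physicochemical assay for lipophilicity (on this read-out lower numbers stand for lower lipophilicity and higher numbers for higher lipophilicity), compound 1 (`Cc1nc(C)c(C(=O)NCC(=O)Oc2ccc(-c3cc(=O)c4c(O)c(O)c(O)cc4o3)cc2)nc1C`) gives 2.8 and compound 2 (`Cc1nc(C)c(C(=O)N[C@@H](C(=O)Oc2ccc(-c3cc(=O)c4c(O)c(O)c(O)cc4o3)cc2)C(C)C)nc1C`) gives 1.38, the lower of the two numbers measured so far. Compound 3 (`Cc1nc(C)c(C(=O)N[C@H](CC(C)C)C(=O)Oc2ccc(-c3cc(=O)c4c(O)c(O)c(O)cc4o3)cc2)nc1C`) has not yet been measured. Compared with compound 2, it has isobutyl in place of isopropyl on a saturated chain carbon bound to an amide-type nitrogen and a carbonyl carbon. Going by the values given here, only one measured step bears on this carbon, a large one with isopropyl in place of hydrogen: a number 1.42 log units lower from compound 1 to compound 2 (beyond the scatter). That step shows that the number can move far at this carbon, but it does not measure a swap of isopropyl for isobutyl. In this assay, a small upward change is therefore expected, a number 0.22 log units higher from compound 2 to compound 3 (within the scatter). With so little evidence, the expected range is wide. The estimate for compound 3 is 1.6, with a range from 1 to 2.4.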

Compound 3, partition coefficient: 0.91
Compound 3: the middle estimate sits 0.69 log units above what was measured; measured number outside the range, below it.
By their numbers in this assay, from the lowest: compound 3; then compound 2; then compound 1.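

In this assay, exchanging one chain for another on this saturated chain carbon bound to an amide-type nitrogen and a carbonyl carbon still moves the number, a number 0.47 log units lower from compound 2 to compound 3 (beyond the scatter), so the change is not confined to the replacement of hydrogen. Measured against hydrogen, isobutyl gives a larger step than isopropyl did, a number 1.89 log units lower from compound 1 to compound 3 (beyond the scatter), and across these three compounds the number falls as the carbon count of the group at this place rises, with none of them going against that order. Nothing available gives a reason for this direction.

The compounds shown leave open whether a longer chain, such as an unbranched hexyl group, would continue the fall. They also leave open how the number would respond to an amine or a carboxylic acid at this place.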